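From formyl to carboxy on compound 1

The compounds below may be only part of what the source reports. "The series", "measured", "known", "first", "only" and "open" are said of these compounds alone.

compound 1 `COc1ccc(C(=O)Nc2ccc(-c3ccc(C=O)cc3C)cc2)cc1CCCN(C)C` 8.4
compound 2 `COc1ccc(NC(=O)c2ccc(-c3ccncc3)cc2)cc1N1CCN(C)CC1` 8
compound 3 `COc1ccc(NC(=O)c2ccc(-c3ccc(C(=O)N(C)C)cc3C)cc2)cc1N1CCN(C)CC1` 9.2

In a functional assay (Saphenous vein) with Canis familiaris (Canis lupus familiaris) as the target (on this read-out lower numbers stand for lower potency and higher numbers for higher potency (the scale is a negative logarithm)), compound 1 gives 8.4 and stands in the middle, above compound 2 and below compound 3, with both gaps beyond the scatter. Compound 4 `COc1ccc(C(=O)Nc2ccc(-c3ccc(C(=O)O)cc3C)cc2)cc1CCCN(C)C` carries a single change: hydroxy in place of hydrogen on a carbonyl carbon, so formyl becomes carboxy. For the measured compounds named here, only one measured step bears on this, and only loosely: a number 1.20 log units higher from compound 2 to compound 3 (beyond the scatter) is a large rise on a different core. It shows that changing that aromatic group can move the number considerably. Going by the values given here, no measured compound carries carboxy, so the direction remains uncertain, though a modest fall seems likeliest. The expected change is a number 0.40 log units lower from compound 1 to compound 4 (beyond the scatter) by this estimate. For compound 4 the estimate is 8 with 7.3 to 8.7 as the expected range.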

Compound 4, negative logarithm of the antagonist equilibrium constant: 8.7
The estimate for compound 4 lay 0.70 log units below the measured number, within the range that was stated.
By their numbers in this assay, from the lowest: compound 2; then compounds 1 and 4 (each within the scatter of the next); then compound 3.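

Replacing formyl with carboxy gives a number 0.30 log units higher from compound 1 to compound 4 (within the scatter) in this assay, so this assay does not separate the two compounds. Hydroxy can therefore be added on this carbonyl carbon without a change beyond the scatter, which the earlier compounds could not show, as none carries carboxy. Nothing available explains this result.

The compounds shown leave open how a methyl ester, a primary amide or a hydroxymethyl group would read in place of carboxy. From the compounds shown here alone, whether carboxy would give a similar number on the core of compound 3 also remains open.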